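The source may hold more compounds than are shown below. What is called first, only, known or untested is meant among the compounds shown, and "the series" means these compounds.

Measured so far in a functional assay on A549 cells (Homo sapiens) for inhibition, read by sulforhodamine B assay, with a stated time of 72 h; on this read-out higher numbers stand for weaker inhibition and lower numbers for stronger inhibition:
compound 1, `COc1cc2c(Nc3ccc(OCc4cccc(F)c4)c(Cl)c3)ncnc2cc1OCCCCCn1ccnc1[N+](=O)[O-]`, gives 19900 nM.
compound 2, `COc1cc2c(Nc3ccc(OCc4cccc(F)c4)c(Cl)c3)ncnc2cc1OCCCCCCn1ccnc1[N+](=O)[O-]`, reaches only the limit of this assay, > 50000 nM.
compound 3, `COc1cc2c(Nc3cccc(Br)c3)ncnc2cc1OCCCCCn1ccnc1[N+](=O)[O-]`, gives 8780 nM.

Compound 1 and compound 3 carry the same chain ending in the nitroimidazole, set on different cores; the difference between the two cores is not broken down here. Of the two numbers, compound 3 holds the lower one, and compound 1 with 19900 nM sits a step above it that lies beyond the usual scatter. The value of compound 2 is a limit and not a number.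

Within the core of compound 1, the change (2-nitro-1H-imidazol-1-yl)methyl in place of 2-nitro-1H-imidazol-1-yl on a saturated chain carbon, five bonds along the chain from an oxygen on an aromatic ring moves the read-out in the weaker direction: an at least 2.5-fold higher number from compound 1 to compound 2 (0.40 log units; beyond the scatter). Only the lower bound of that step is known because of the limit of > 50000 nM in this assay, at which 1 of the 3 values shown sits.

Compound 4, `COc1cc2c(Nc3cccc(Br)c3)ncnc2cc1OCCCCCCn1ccnc1[N+](=O)[O-]`, applies the same change to the core of compound 3: (2-nitro-1H-imidazol-1-yl)methyl in place of 2-nitro-1H-imidazol-1-yl on a saturated chain carbon, five bonds along the chain from an oxygen on an aromatic ring. The place is described in the same words for both pairs, so the change is taken as the same one. Compound 4 is expected to weaken by a step of the same kind, a 2.8-fold higher number from compound 3 to compound 4 (0.45 log units; beyond the scatter), resting on the step of an at least 2.5-fold higher number from compound 1 to compound 2 (0.40 log units; beyond the scatter) and on the starting value of compound 3, 8780 nM. The estimate for compound 4 in this assay is 25000 nM, with an expected range from 10000 nM to 60000 nM; since compound 2 reached the limit, compound 4 may do so as well.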

Compound 4, half-maximal inhibitory concentration: 30200 nM
Beside the measured number, compound 4's estimate is 1.2-fold (0.08 log units) below it; the range from low to high includes it.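

Working notes on the chain change: in this assay, (2-nitro-1H-imidazol-1-yl)methyl in place of 2-nitro-1H-imidazol-1-yl, on a saturated chain carbon, five bonds along the chain from an oxygen on an aromatic ring, gives a 3.4-fold higher number from compound 3 to compound 4 (0.54 log units; beyond the scatter), so the read-out moves in the weaker direction on the core of compound 3 as well. Set beside the core of compound 1, the direction carries over from one core to the other, while the comparison of sizes stays unsettled: the same change on two cores in this assay, an at least 2.5-fold higher number (0.40 log units; beyond the scatter) from compound 1 to compound 2 and a 3.4-fold higher number (0.54 log units; beyond the scatter) from compound 3 to compound 4; the limit leaves it open whether they differ Compound 2 stands at a limit of the assay and not at a number, so the carry-over is shown for direction only, on these two cores and this one pair of chain lengths, and a fixed size for the step is not shown: the limit of > 50000 nM in this assay, at which 1 of the 4 values shown sits.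

Open is how the read-out in this assay runs on either core with a shorter or a still longer chain, since the compounds shown cover only these two lengths. Also open, on these data alone, is whether the same step holds when an amine or a carboxylic acid stands at the chain end in place of 2-nitro-1H-imidazol-1-yl.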